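Microsomal stability of the side chain: from compound 1 to compound 4

The compounds below may be only part of what the source reports. "The series", "measured", "known", "first", "only" and "open" are said of these compounds alone.

Compound 1 `CC(C)(C)NC(=O)NCCS(=O)(=O)NC(=O)c1ccc(Nc2nc(NC3(c4ccc(Cl)cc4)CC3)nc(OCC(F)(F)F)n2)cc1` is tested in an ADME assay on microsomes from liver (Rattus norvegicus) for metabolic stability, with a stated time of 10 min (a lower number here means that less of the compound is left, a higher number that more of the compound is left), where compound 1 gives 93%. Compound 2 `CC(C)(C)OC(=O)NCCS(=O)(=O)NC(=O)c1ccc(Nc2nc(NC3(c4ccc(Cl)cc4)CC3)nc(OCC(F)(F)F)n2)cc1` gives 93% in this assay, and compound 3 `CC(C)NC(=O)NCCS(=O)(=O)NC(=O)c1ccc(Nc2nc(NC3(c4ccc(Cl)cc4)CC3)nc(OCC(F)(F)F)n2)cc1` gives 97%. Compound 1 thus stands level with compound 2, together the lowest of the three numbers, and the gap to compound 3 is a number 4 percentage points higher from compound 1 to compound 3 (within the scatter). The measured steps are small throughout: no change at the digits printed from compound 1 to compound 2 (within the scatter) and a number 4 percentage points higher from compound 2 to compound 3 (within the scatter).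

Compound 4 `O=C(NS(=O)(=O)CCNCc1ccccc1)c1ccc(Nc2nc(NC3(c4ccc(Cl)cc4)CC3)nc(OCC(F)(F)F)n2)cc1` is not yet measured in this assay. It differs from compound 1 as benzyl in place of (tert-butyl)carbamoyl on an amine nitrogen. The measured steps exchange tert-butoxy, (tert-butyl)amino and isopropylamino on a carbonyl carbon, or hydrogen for methyl on a saturated chain carbon; none of them removes the carbonyl carbon itself, which compound 4 does. They therefore bear only loosely on this change. Given the narrow spread among compounds 1, 2 and 3, no large shift is expected, but the move to a benzyl group is uncharted, so the expected step is a number 11 percentage points lower from compound 1 to compound 4 (beyond the scatter) with a wide band. Compound 4 is estimated at 82%, expected between 55% and 97%.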

Compound 4, percent of the compound remaining: 100%
Compound 4: the middle estimate sits 18 percentage points below what was measured, and the stated range ends below it.
By their numbers in this assay, from the lowest: compounds 1, 2, 3 and 4 (each within the scatter of the next).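

In this assay, replacing the carbonyl-bearing group on the amine nitrogen with benzyl gives a number 7 percentage points higher from compound 1 to compound 4 (within the scatter), a number 7 percentage points higher from compound 2 to compound 4 (within the scatter) and a number 3 percentage points higher from compound 3 to compound 4 (within the scatter). This position therefore holds the read-out with a group that has no carbonyl carbon, no hydrogen-bond donor or acceptor and a six-membered aromatic ring of carbon only, so the carbonyl is not required for these numbers, and with compound 4 at 100% the read-out has no room left above it. Nothing at hand bears on the reason for this flat picture.

Still open, as far as these compounds go, is whether any group on this nitrogen moves the number beyond the scatter, for example a carboxylic acid on the benzyl ring or a bare amine with hydrogen in place of benzyl. A longer chain in place of the 2-(benzylamino)ethyl group is equally untested by the compounds shown here.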